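One amine swap on a compound at the assay limit

The source may hold more compounds than are shown below. What is called first, only, known or untested is meant among the compounds shown, and "the series" means these compounds.

Compound 1 `CCOC(=O)c1cc(=O)c2cc(CSC(=S)N(C)c3ccccc3)ccc2o1` was tested in a functional assay on MCF7 cells (Homo sapiens) for antiproliferative activity, read by MTT assay, with a stated time of 72 h; a lower number here means a stronger inhibitor, a higher number a weaker inhibitor. In this assay compound 1 gives > 25000 nM, which is a limit of the measurement rather than a number, so compound 1 stands at the edge of what can be read, as shown by the limit of > 25000 nM in this assay, at which 1 of the 3 values shown sits. Two compounds built on different cores were also measured: compound 2 `O=c1c(CSC(=S)N2CCCCC2)coc2cc(Cl)ccc12` gives 380 nM in this assay, and compound 3 `O=c1c(Cl)c(CSC(=S)N2CCCC2)oc2ccccc12` gives 2300 nM. Compound 4 `CCOC(=O)c1cc(=O)c2cc(CSC(=S)N3CCCCC3)ccc2o1` differs from compound 1 by one change: piperidin-1-yl in place of methyl(phenyl)amino on a thiocarbonyl carbon. Within the data shown here, no measured pair isolates this change, so its effect rests on expectation alone. Compound 4 is expected to move from the limit into measurable territory, a step of an at least 3.1-fold lower number from compound 1 to compound 4 (0.49 log units; beyond the scatter). The estimate for compound 4 is 8000 nM, ranging from 1500 nM to 30000 nM.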

Compound 4, half-maximal inhibitory concentration: 21900 nM
Compound 4: the middle estimate sits 2.7-fold (0.44 log units) below what was measured; measured number inside the range.
By their numbers in this assay, from the lowest: compound 2; then compound 3; then compound 4. At a limit, above all of these: compound 1.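

In this assay, piperidin-1-yl in place of methyl(phenyl)amino on a thiocarbonyl carbon gives an at least 1.1-fold lower number from compound 1 to compound 4 (0.05 log units; that floor lies within the scatter). Compound 4 does give a readable number, 21900 nM, but this swap alone leaves it weak on the core of compound 1. The value of compound 1 is a limit, not a number, so the true size of the step cannot be read: the limit of > 25000 nM in this assay, at which 1 of the 4 values shown sits.

Still open, going by these compounds, is how morpholin-4-yl or diethylamino would read on that thiocarbonyl carbon. Also open, on these data alone, is whether a carboxylic acid in place of the ethyl ester would change the number of compound 4.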